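Benzyloxy on the ring nitrogen of the ester series

This account rests on a few compounds, and the source may have more. Where it says the series, first, only, none or still open, it means among the compounds named here.

Measured so far:
compound 1 `CCOC(=O)c1c(C)nc(-c2cccc(C#N)c2)n1C(C)C` — 9260 nM
compound 2 `CCOC(=O)c1c(C)nc(-c2cccc(C#N)c2)n1OCCCO` — 11400 nM

Both numbers come from a functional assay on a cell-free system (plasma, Oryctolagus cuniculus) for inhibition, with stated times of 5 min, 1 min and 6 min; a higher number here means a weaker inhibitor, a lower number a stronger inhibitor. Compound 1 and compound 2 share the whole core and differ only at the aromatic nitrogen, where compound 2 carries 3-hydroxypropoxy in place of isopropyl; the step of a 1.2-fold higher number from compound 1 to compound 2 (0.09 log units; within the scatter) is within the scatter, so the two numbers cannot be told apart and compound 1 stands level with compound 2 on the numbers shown.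

Compound 3 `CCOC(=O)c1c(C)nc(-c2cccc(C#N)c2)n1OCc1ccccc1` is the next member to be tested in this assay. Against compound 1 the change is benzyloxy in place of isopropyl on an aromatic nitrogen. Within the data shown here, the only step that bears on it is the one from compound 1 to compound 2, which also swaps the isopropyl on this nitrogen for an oxygen-linked group and moved the number by a 1.2-fold higher number from compound 1 to compound 2 (0.09 log units; within the scatter) only. On that single step the expectation is no change beyond the scatter, in either direction, and the step from compound 1 to compound 3 is estimated at a 1.1-fold higher number from compound 1 to compound 3 (0.03 log units; within the scatter). Compound 3 is therefore expected to give about 10000 nM in this assay, with a range from 4000 nM to 25000 nM.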

Compound 3, half-maximal inhibitory concentration: 5930 nM
Estimate against measurement, compound 3: 1.7-fold (0.23 log units) above, within the range that was stated.
By their numbers in this assay, from the lowest: compounds 3, 1 and 2 (each within the scatter of the next).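

In this assay the step of a 1.6-fold lower number from compound 1 to compound 3 (0.19 log units; within the scatter) lies within the scatter, so the aromatic nitrogen carries benzyloxy, with 8 heavy atoms and one six-membered aromatic ring of carbon only, in place of isopropyl, with 3 heavy atoms and no ring, with no change that can be read. The step of a 1.9-fold lower number from compound 2 to compound 3 (0.28 log units; within the scatter) is also within the scatter, so phenyl in place of 2-hydroxyethyl on the saturated chain carbon bound to the oxygen gives no separation, and isopropyl, 3-hydroxypropoxy and benzyloxy cannot be told apart at this position on these numbers. Nothing at hand bears on the reason for this result.

All three compounds keep the ethoxycarbonyl group, the methyl group and the rest of the shared core unchanged, so the reading holds for this position alone. As far as these compounds go, whether a terminal amine or carboxylic acid on the oxygen-linked chain, a longer chain, or a chloro substituent on the benzyloxy ring would give a step beyond the scatter remains open.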